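From 4-Fluorophenyl to a Pyrimidine-Bearing Pyrrolidinone

A few compounds are considered here, and "the series" means these few. Any claim that something is new, unique, unknown or untested is made for them only; others in the source may bear on it.

In a toxicity assay on HepG2 2.2.15 cells (Homo sapiens) for cytotoxicity, read by CellTiter-Glo (on this read-out lower numbers stand for higher toxicity in this test and higher numbers for lower toxicity in this test), compound 3 (`O=C(Nc1cc(F)c(F)c(F)c1)N1Cc2c(-c3ccc(F)cc3)cnn2CC1C1CC1`) gives 38500 nM and stands level with compound 2 (`O=C1c2ccccc2CN1c1cnn2c1CN(C(=O)Nc1cc(F)c(F)c(F)c1)C(C1CC1)C2`) at 38500 nM as the lowest of three numbers. Compound 1 (`O=C1CC(C(F)(F)F)CN1c1cnn2c1CN(C(=O)Nc1cc(F)c(F)c(F)c1)C(C1CC1)C2`) stands higher at 115000 nM on the same read-out. Compound 4 (`O=C1CC(c2ncccn2)CN1c1cnn2c1CN(C(=O)Nc1cc(F)c(F)c(F)c1)C(C1CC1)C2`) is not yet measured and carries 2-oxo-4-(pyrimidin-2-yl)pyrrolidin-1-yl in place of 4-fluorophenyl on an aromatic carbon. The nearest guide is compound 1, which holds 2-oxo-4-(trifluoromethyl)pyrrolidin-1-yl on that carbon, and its swap for 4-fluorophenyl gave a 3.0-fold lower number from compound 1 to compound 3 (0.48 log units; beyond the scatter) in the measurements. Compound 2 argues for caution: its group also joins a five-membered non-aromatic ring to an aromatic ring, yet it gave a 3.0-fold lower number from compound 1 to compound 2 (0.48 log units; beyond the scatter) as well as no change at the digits printed from compound 2 to compound 3 (within the scatter) on the way to the fluorophenyl compound. A modest rise in this assay is therefore expected, estimated as a 2.1-fold higher number from compound 3 to compound 4 (0.32 log units; beyond the scatter) from these steps. For compound 4 the estimated value is 80000 nM with an expected range from 35000 nM to 180000 nM on this read-out.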

Compound 4, half-maximal cytotoxic concentration: > 200000 nM
Compound 4 was reported as a limit (the forecaster's own chance of this, stated with the estimate: 25%); middle value at least 2.5-fold (0.39 log units) from the limit.
By their numbers in this assay, from the lowest: compounds 2 and 3 (each within the scatter of the next); then compound 1. At a limit, above all of these: compound 4.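

In this assay, compound 4 is reported as a limit and not as a number: the limit of > 200000 nM in this assay, at which 1 of the 4 values shown sits. With 2-oxo-4-(pyrimidin-2-yl)pyrrolidin-1-yl on this aromatic carbon, the data show an at least 5.1-fold higher number from compound 3 to compound 4 (0.71 log units; beyond the scatter) and an at least 5.1-fold higher number from compound 2 to compound 4 (0.71 log units; beyond the scatter), so a five-membered non-aromatic ring together with a six-membered aromatic ring does not by itself fix the number, since compound 2 also carries both ring types. Within the pyrrolidinone group, pyrimidin-2-yl in place of trifluoromethyl gives an at least 1.7-fold higher number from compound 1 to compound 4 (0.24 log units; that floor lies within the scatter) and, with that floor inside the scatter, this swap cannot be called a true rise.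

Going by these compounds, how far the true value of compound 4 lies past its limit remains open. Also open, on these data alone, is whether a plain phenyl or an amine on that saturated ring carbon would behave like pyrimidin-2-yl or like trifluoromethyl.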